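The source may report more compounds than this note shows. Statements on the series, on what has been measured and on what is new or still open speak of the compounds shown alone.

The measured compounds:
Compound 1, `Cc1oc(C(=O)O)cc1COc1ccc(-c2nnco2)cc1`, in an assay on cells for displacement of a labelled ligand from prostaglandin E2 receptor EP4 subtype (Homo sapiens), read by scintillation counting (a higher number here means a weaker inhibitor, a lower number a stronger inhibitor), gives > 10000 nM, which is a limit of the assay and not a number.
Compound 2, `CC(C(=O)Nc1ccccc1Cc1ccccc1C(=O)O)c1cccc2ccccc12`, in this assay gives 7 nM.
Compound 3, `O=C(O)c1cc(COc2ccc(-c3ccccc3)cc2)co1`, in this assay gives 2000 nM.

Compound 1 sits at the edge of what the assay can report: the limit of > 10000 nM in this assay, at which 1 of the 3 values shown sits. Compound 2 and compound 3, built on different cores, both return measured numbers, with compound 3 weaker than compound 2.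

The next compound, compound 4, `Cc1oc(C(=O)O)cc1COc1ccc(-c2ccoc2)cc1`, keeps the whole core of compound 1 and changes one group: furan-3-yl in place of 1,3,4-oxadiazol-2-yl on an aromatic carbon. Compound 3 carries a phenyl at a similar position and gives 2000 nM, but it also lacks the methyl of compound 1, so the two values alone cannot separate the two differences.

Still, a ring built from carbon and one oxygen lies closer to the phenyl of compound 3 than to the 1,3,4-oxadiazol-2-yl of compound 1. The step of an at least 3.3-fold lower number from compound 1 to compound 4 (0.52 log units; beyond the scatter) is therefore expected to move toward stronger binding, beyond the usual scatter, though compound 4 may still land at the limit. Compound 4 is estimated at 3000 nM, with a range from 800 nM to 15000 nM.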

Compound 4, inhibition constant: > 10000 nM
Compound 4: no number, only a limit; the forecaster's own chance of this, stated with the estimate: 35%; at least 3.3-fold (0.52 log units) between middle value and limit.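

In this assay compound 4 gives > 10000 nM, which is a limit of the assay and not a number. Compound 1 also stands at a limit, so no step between compound 1 and compound 4 can be read: the limit of > 10000 nM in this assay, at which 2 of the 4 values shown sit.

Left open is whether furan-3-yl and 1,3,4-oxadiazol-2-yl differ in binding at all, and how far past the limit either compound lies.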